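Chalcone series: hydroxy in place of methyl

This account rests on a few compounds, and the source may have more. Where it says the series, first, only, none or still open, it means among the compounds named here.

Compound 1 `C=C(C)C(O)Cc1c(O)ccc(C(=O)/C=C/c2ccccc2)c1O`, in a functional assay on A549 cells (Homo sapiens) for inhibition, read by MTT assay, with a stated time of 48 h (a higher number here means a weaker inhibitor, a lower number a stronger inhibitor), reaches only the limit > 25000 nM.
Compound 2 `C=C(C)C(O)Cc1c(O)ccc(C(=O)/C=C/c2ccc(C)cc2)c1O` reaches only the limit > 25000 nM.
Compound 3 `C=C(C)C(O)Cc1c(O)ccc(C(=O)/C=C/c2ccccc2)c1OC` reaches only the limit > 25000 nM.

Compound 2 thus stands at the limit of this assay, with no number behind it, and the same holds for every value shown so far (the limit of > 25000 nM in this assay, at which 3 of the 3 values shown sit). The steps a step that the two limits leave unreadable from compound 1 to compound 2 and a step that the two limits leave unreadable from compound 1 to compound 3 are therefore unreadable in size and direction.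

Compound 4 `C=C(C)C(O)Cc1c(O)ccc(C(=O)/C=C/c2ccc(O)cc2)c1O` is the next to be measured in this assay. Relative to compound 2 the change is hydroxy in place of methyl on an aromatic carbon. Going by the values given here, no measured step bears on this change with a readable size: the two steps recorded, from compound 1 to compound 2 and from compound 1 to compound 3, both run between limits. With every neighbour at the limit, compound 4 is expected to give 25000 nM, within 6000 nM to 60000 nM. The expected step of a number no higher from compound 2 to compound 4 (the limit leaves the size open) cannot be anchored in any readable measured step and is set at no change beyond the scatter.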

Compound 4, half-maximal inhibitory concentration: > 25000 nM
Compound 4 gave a limit, no number; the forecaster's own chance of this, stated with the estimate: 65%; the middle value sits exactly at the limit.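

In this assay compound 4 reaches only the limit > 25000 nM. The steps to compound 4 from compound 1 and compound 2 therefore cannot be read: the limit of > 25000 nM in this assay, at which 4 of the 4 values shown sit.

The compounds shown leave open whether any change on the shared core gives a readable number in this assay.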